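Anilino-quinazoline series: shifting the hydroxyl on the aniline

The source may hold more compounds than are shown below. What is called first, only, known or untested is meant among the compounds shown, and "the series" means these compounds.

Measured compounds:
compound 1 `COc1ccc(Nc2nc(-c3cccc(F)c3)nc3ccc(F)cc23)cc1`, 38600 nM
compound 2 `Fc1ccc(Nc2nc(-c3cccc(F)c3)nc3ccc(F)cc23)cc1`, > 50000 nM
compound 3 `Oc1cccc(Nc2nc(-c3cccc(F)c3)nc3ccc(F)cc23)c1`, > 50000 nM

For the measured compounds named here, in a functional assay on HL-60 cells (Homo sapiens) for cytotoxicity, read by MTT assay, with a stated time of 48 h (a lower number here means a stronger inhibitor, a higher number a weaker inhibitor), compound 1 gives 38600 nM, the only numerical value in the set. For compound 2 the result is a limit of the assay, > 50000 nM. For compound 3 likewise only a limit is recorded, > 50000 nM. Compound 1 is therefore the sole reference point with a number, and the two steps away from it, an at least 1.2-fold higher number from compound 1 to compound 2 (0.11 log units; that floor lies within the scatter) and an at least 1.2-fold higher number from compound 1 to compound 3 (0.11 log units; that floor lies within the scatter), each have a floor that lies within the scatter, so neither reads as a real change. The pair compound 2 and compound 3 gives a step that the two limits leave unreadable from compound 2 to compound 3.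

Compound 4 `Oc1ccccc1Nc1nc(-c2cccc(F)c2)nc2ccc(F)cc12` differs from compound 1 in that (2-hydroxyphenyl in place of 4-methoxyphenyl on a nitrogen on an aromatic ring). Going by the values given here, the closest measured step is the one to compound 3, where the hydroxyl enters at another ring position and the number rose at least to the limit (the limit of > 50000 nM in this assay, at which 2 of the 3 values shown sit). For this assay a step of a 1.3-fold higher number from compound 1 to compound 4 (0.11 log units; within the scatter) is expected, toward a weaker inhibitor or none beyond the scatter, with a real chance that compound 4 also reports only a limit. Compound 4 is estimated at 50000 nM, within 25000 nM to 100000 nM.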

Compound 4, half-maximal inhibitory concentration: 44400 nM
Compound 4: middle estimate off by 1.1-fold (0.05 log units), on the high side; the measured number falls inside the stated range.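

In this assay compound 4 gives 44400 nM, a number and not a limit, so a hydroxyl-bearing ring on this nitrogen can now be compared directly with the 4-methoxyphenyl of compound 1. That comparison gives a 1.2-fold higher number from compound 1 to compound 4 (0.06 log units; within the scatter), so the ring with a hydrogen-bond donor and the ring without one do not separate at this place. The two remaining steps, an at least 1.1-fold lower number from compound 3 to compound 4 (0.05 log units; that floor lies within the scatter) and an at least 1.1-fold lower number from compound 2 to compound 4 (0.05 log units; that floor lies within the scatter), have floors that do not separate 2-hydroxyphenyl from 3-hydroxyphenyl or from 4-fluorophenyl, and both partners remain limits: the limit of > 50000 nM in this assay, at which 2 of the 4 values shown sit.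

Every group shown on this nitrogen therefore leaves the series without a step beyond the scatter, and the data do not show whether any change at this place can produce one. On these data alone, it remains open whether an amine or a carboxylic acid in place of the hydroxyl of the 2-hydroxyphenyl group, or a longer chain such as hydroxyethyl carrying that hydroxyl, would move the number beyond the scatter in this assay.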